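This account rests on a few compounds, and the source may have more. Where it says the series, first, only, none or still open, it means among the compounds named here.

Measured so far in a physicochemical assay, with a stated time of 6 min; on this read-out lower numbers stand for stronger inhibition and higher numbers for weaker inhibition:

Compound 1 `O=C(Nc1ccc([N+](=O)[O-])cc1)Nc1nc(-c2cc3cc(Br)ccc3o2)cs1`: > 200000 nM
Compound 2 `O=C(Nc1nc(-c2cc3cc(Br)ccc3o2)cs1)Nc1ccccc1F`: > 200000 nM
Compound 3 `COc1ccc(NC(=O)Nc2nc(-c3cc4cc(Br)ccc4o3)cs2)cc1`: > 200000 nM

All of the evidence so far is the limit of > 200000 nM in this assay, at which 3 of the 3 values shown sit. Compound 3 stands at > 200000 nM, which is a limit of the assay and not a number, so it has no rank among the three.

The next compound is compound 4 `O=C(Nc1nc(-c2cc3cc(Br)ccc3o2)cs1)Nc1ccccc1[N+](=O)[O-]`. Its structural change from compound 3 is 2-nitrophenyl in place of 4-methoxyphenyl on an amide-type nitrogen. In short, 2-nitrophenyl takes the place of 4-methoxyphenyl on an amide-type nitrogen.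

Among the compounds with values here, three measured steps bear on this change, all among the groups carried on that nitrogen: a step that the two limits leave unreadable from compound 1 to compound 2, a step that the two limits leave unreadable from compound 1 to compound 3 and a step that the two limits leave unreadable from compound 2 to compound 3. None of them has a size that can be read. The closest match to the incoming group is the 4-nitrophenyl of compound 1, whose reading of > 200000 nM is likewise a limit.

Within the data shown here, no step of readable size is therefore expected in this assay, and no direction can be expected either. The estimated move is a number no higher from compound 3 to compound 4 (the limit leaves the size open), and another reading at the limit is the likeliest outcome. Compound 4 is expected at 200000 nM, with an estimated range from 100000 nM to 400000 nM.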

Compound 4, half-maximal inhibitory concentration: 166000 nM
Compound 4: the middle estimate sits 1.2-fold (0.08 log units) above what was measured; measured number inside the range.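

In this assay compound 4 gives 166000 nM, and with the 2-nitrophenyl on the amide-type nitrogen the series gains its first reading that is a number and not a limit: the limit of > 200000 nM in this assay, at which 3 of the 4 values shown sit.

Set against the three limits, this reading yields an at least 1.2-fold lower number from compound 3 to compound 4 (0.08 log units; that floor lies within the scatter), an at least 1.2-fold lower number from compound 2 to compound 4 (0.08 log units; that floor lies within the scatter) and an at least 1.2-fold lower number from compound 1 to compound 4 (0.08 log units; that floor lies within the scatter), so each of these steps is only a floor, and none of them by itself shows a change beyond the usual scatter. The steps among compound 1, compound 2 and compound 3 still cannot be read, so the 2-nitrophenyl can be placed against the other groups on that nitrogen only through these floors.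

On these data alone, how far the true values of compound 1, compound 2 and compound 3 lie from compound 4 stays open, and with it whether 2-nitrophenyl really differs from 4-nitrophenyl or from the other two groups. The compounds shown also leave open what an amine or a carboxylic acid would give in place of the nitro on that aromatic carbon, and whether any such group would bring the number down by more than the scatter.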